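The compounds below may be only part of what the source reports. "The series", "measured", "known", "first", "only" and "open" are said of these compounds alone.

Compound 1 `CN1CCN(C(=S)SCC2=CCOC2=O)CC1`, compound 2 `CCNC(=S)SCC1=CCOC1=O` and compound 3 `O=C1OCC=C1CSC(=S)NCc1ccccc1` share one core and differ only in the group on the thiocarbonyl carbon. In a functional assay on HeLa cells (Homo sapiens) for antiproliferative activity, read by MTT assay, with a stated time of 72 h (a higher number here means a weaker inhibitor, a lower number a stronger inhibitor), compound 1 gives 770 nM, and compound 3 gives 15100 nM. Going by the values given here, compound 2 stands apart from these two: in this assay compound 2 is recorded as "not active" (no number reported), so no single number fixes where it lies, and no step from compound 2 can be counted.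

Compound 4 `O=C1OCC=C1CSC(=S)N1CCCC1` is the not yet measured member. It differs from compound 2 by pyrrolidin-1-yl in place of ethylamino on a thiocarbonyl carbon. Among the compounds with values here, no measured pair shows this exact change, so the size of the step is a matter of expectation only. Compound 1, which also carries a ring closed on the thiocarbonyl nitrogen, gives 770 nM, whereas the open-chain compound 2 and compound 3 gave no number and 15100 nM; on that basis compound 4 is expected to be stronger than compound 2, by a step beyond the scatter, though not necessarily reaching compound 1. Compound 4 is therefore estimated at 3000 nM, within a range from 800 nM to 20000 nM.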

Compound 4, half-maximal inhibitory concentration: 2630 nM
The estimate for compound 4 lay 1.1-fold (0.06 log units) above the measured number; the range from low to high includes it.
By their numbers in this assay, from the lowest: compound 1; then compound 4; then compound 3.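

In this assay, going by these compounds alone, compound 2 has no number, so no step to compound 4 can be read. The compounds shown leave open how large the change from ethylamino to pyrrolidin-1-yl is. Nothing measured here offers a cause for the value of compound 4.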